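The source may hold more compounds than are shown below. What is called first, only, known or untested is meant among the compounds shown, and "the series" means these compounds.

Compound 1 `CCCCNc1nc(N)nc2c1CN(C(=O)c1ccccc1)CC2` and compound 2 `CCCCNc1nc(N)nc2c1CCN(C(=O)c1ccccc1)C2` are built from the same atoms joined differently; the difference between the two cores is not broken down here. In an assay on HEK293 cells for agonist activity at Toll-like receptor 8 (Homo sapiens), read by a luciferase reporter, with a stated time of 6 h (on this read-out lower numbers stand for an effect already at smaller amounts and higher numbers for an effect only at larger amounts of compound), compound 1 gives 1.4 uM, and compound 2 gives 0.8 uM, two results that lie within the scatter of each other. Compound 3 `CCCCNc1nc(N)nc2c1CN(S(C)(=O)=O)CC2` carries the change (methylsulfonyl in place of benzoyl on an amine nitrogen in a ring). In this assay compound 3 gives 9.9 uM, so that a 7.1-fold higher number from compound 1 to compound 3 (0.85 log units; beyond the scatter). Compound 4 `CCCCNc1nc(N)nc2c1CCN(S(C)(=O)=O)C2` is not yet measured; it carries the same change, (methylsulfonyl in place of benzoyl on an amine nitrogen in a ring), made on the core of compound 2 instead of the core of compound 1. Because a 7.1-fold higher number from compound 1 to compound 3 (0.85 log units; beyond the scatter), a step of similar size is expected here: a 7.1-fold higher number from compound 2 to compound 4 (0.85 log units; beyond the scatter). On that basis compound 4 is expected to give about 5.7 uM in this assay, with a likely range from 2.5 uM to 13 uM.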

Compound 4, minimum effective concentration: 0.8 uM
Beside the measured number, compound 4's estimate is 7.1-fold (0.85 log units) above it; the measured number lies below the stated range.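

In this assay, putting methylsulfonyl in place of benzoyl on the ring nitrogen gives no change at the digits printed from compound 2 to compound 4 (within the scatter). The change therefore does not carry over as a fixed step, and its size depends on the core that bears it: the same change on two cores in this assay, a 7.1-fold higher number (0.85 log units; beyond the scatter) from compound 1 to compound 3 and no change at the digits printed (within the scatter) from compound 2 to compound 4, 7.1-fold (0.85 log units) apart, beyond the scatter of two such steps

This rests on a single change made on just two cores, so it shows that such a transfer can fail here, but not why the two cores respond differently or how any other group would behave. The compounds shown leave open whether a smaller acetyl group or a sulfonyl group bearing a longer chain on the same ring nitrogen would also give different steps on the two cores.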